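A few compounds are considered here, and "the series" means these few. Any claim that something is new, unique, unknown or untested is made for them only; others in the source may bear on it.

Compound 1, `Brc1cn2ccnc2c(-c2ccc3ncn(C4CCCCC4)c3c2)n1`, gives 18% in a functional assay on K562 cells (Homo sapiens) for inhibition, read by sulforhodamine B assay, with a stated time of 48 h, tested at 10 uM (a higher number here means more inhibition at the concentration tested (going by the name of the read-out), a lower number less inhibition), and it stands lowest of the three measured compounds. Two analogues in which an aromatic group takes the place of the bromine on the same carbon of the shared core are known. Compound 2, `c1ccc2c(-c3cn4ccnc4c(-c4ccc5ncn(C6CCCCC6)c5c4)n3)cccc2c1`, gives 30.9% in this assay, a rise of a number 12.9 percentage points higher from compound 1 to compound 2 (beyond the scatter). Compound 3, `Clc1ccc(-c2cn3ccnc3c(-c3ccc4ncn(C5CCCCC5)c4c3)n2)cc1`, gives 44.5% in this assay, a rise of a number 26.5 percentage points higher from compound 1 to compound 3 (beyond the scatter); between these two aromatic groups the step is a number 13.6 percentage points higher from compound 2 to compound 3 (beyond the scatter).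

Compound 4, `c1csc(-c2cn3ccnc3c(-c3ccc4ncn(C5CCCCC5)c4c3)n2)c1`, differs from compound 1 in one place: thiophen-2-yl in place of bromo on an aromatic carbon. Both measured steps from compound 1 bear on this change, since each also puts an aromatic group in place of the bromine at that carbon, and both ran upward by a modest amount beyond the scatter. A rise of similar size is therefore expected, so that the step is estimated at a number 16 percentage points higher from compound 1 to compound 4 (beyond the scatter). Compound 4 is accordingly expected to give about 34% in this assay, with a likely range from 20% to 50%.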

Compound 4, a percentage reported as inhibition, at one concentration (the size of the read-out at that concentration, not a potency): 27%
Compound 4: middle estimate off by 7 percentage points, on the high side, within the range that was stated.
By their numbers in this assay, from the lowest: compounds 1, 4 and 2 (each within the scatter of the next, the first and the last beyond it); then compound 3.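

In this assay, the thiophen-2-yl group does not carry the rise seen with the earlier aromatic groups: the step is a number 9 percentage points higher from compound 1 to compound 4 (within the scatter) and so does not separate it from bromo at this carbon. Set against the other two aromatic groups, the change gives a number 17.5 percentage points lower from compound 3 to compound 4 (beyond the scatter) and a number 3.9 percentage points lower from compound 2 to compound 4 (within the scatter) and thus places thiophen-2-yl clearly apart from 4-chlorophenyl but not from naphthalen-1-yl, so an aromatic group here does not by itself lift the number beyond the scatter from bromo. Nothing at hand explains why these groups differ.

The compounds shown leave open how an amine or a carboxylic acid at this carbon would read in this assay. They also leave open whether a phenyl group without the chlorine would stay with compound 3 or fall with compound 4.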